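Swapping Methyl for Cyano on the Outer Aromatic Ring

The source may report more compounds than this note shows. Statements on the series, on what has been measured and on what is new or still open speak of the compounds shown alone.

Compound 1, `COC(=O)N[C@H]1Cc2ccc(NC(=O)c3cc(C)ccc3-c3ccc(C(F)(F)F)cc3)cc2C1`, gives 170 nM in an assay on isolated protein for inhibition of microsomal triglyceride transfer protein large subunit (Homo sapiens); a lower number here means a stronger inhibitor, a higher number a weaker inhibitor.
Compound 2, `Cc1cccc(C(=O)Nc2ccc3c(c2)CC(NS(=O)(=O)c2ccccc2)C3)c1-c1ccc(F)cc1`, gives 240 nM in this assay.
Compound 3, `Cc1ccc(-c2c(C)cccc2C(=O)Nc2ccc3c(c2)CC(NS(=O)(=O)c2ccccc2)C3)cc1`, gives 93 nM in this assay.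

Compound 3 has the lowest number of the three; its gap to compound 1 lies within the scatter, its gap to compound 2 beyond it. Compound 4, `Cc1cccc(C(=O)Nc2ccc3c(c2)CC(NS(=O)(=O)c2ccccc2)C3)c1-c1ccc(C#N)cc1`, differs from compound 3 by cyano in place of methyl on an aromatic carbon. Within the data shown here, one measured step bears on this place: a 2.6-fold lower number from compound 2 to compound 3 (0.41 log units; beyond the scatter), a modest change. Compound 1, which carries a trifluoromethyl group instead, stands within the scatter of compound 3. Among the measured compounds shown here, no measured step covers cyano itself, so the expected step of a 1.6-fold higher number from compound 3 to compound 4 (0.21 log units; within the scatter) is small, at most a slight rise. Compound 4 is estimated at 150 nM, in a range from 50 nM to 500 nM.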

Compound 4, half-maximal inhibitory concentration: 120 nM
Estimate against measurement, compound 4: 1.3-fold (0.10 log units) above, and the stated range covers the measured number.
By their numbers in this assay, from the lowest: compounds 3, 4, 1 and 2 (each within the scatter of the next, the first and the last beyond it).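

In this assay the change from 4-methylphenyl to 4-cyanophenyl gives a 1.3-fold higher number from compound 3 to compound 4 (0.11 log units; within the scatter) and so brings a hydrogen-bond acceptor to this position with no change beyond the scatter. Cyano in place of fluoro gives a 2.0-fold lower number from compound 2 to compound 4 (0.30 log units; within the scatter) while methyl in place of fluoro gives a 2.6-fold lower number from compound 2 to compound 3 (0.41 log units; beyond the scatter) so only the methyl step stands clear of the scatter. Nothing measured here explains these steps.

As far as these compounds go, whether an amine, a carboxylic acid or a methoxy group would fit this position equally well stays open. So does how cyano would behave on the core of compound 1.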